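A few compounds are considered here, and "the series" means these few. Any claim that something is new, unique, unknown or untested is made for them only; others in the source may bear on it.

Compound 1 `O=C(Nc1ncc([N+](=O)[O-])s1)c1ccc(-c2ccc(Br)cc2)o1` gives 89.1% in an ADME assay on HEK-293T cells (Homo sapiens) for cytotoxicity, read by MTT assay, tested at 25 uM; a higher number here means a weaker effect of the compound at the concentration tested, a lower number a stronger effect.
Compound 2 `Cc1ccc(-c2ccc(C(=O)Nc3ncc([N+](=O)[O-])s3)o2)cc1` gives 94.1% in this assay.

Of these two numbers, compound 2 stands highest, with compound 1 nearest at a gap that lies within the scatter, so the two cannot be told apart; both show only a weak effect at the concentration tested. Compound 3 `COOc1ccc(-c2ccc(C(=O)Nc3ncc([N+](=O)[O-])s3)o2)cc1` differs from compound 2 in one place: methoxyoxy in place of methyl on an aromatic carbon. Within the data shown here, only one measured step offers any comparison, a number 5 percentage points higher from compound 1 to compound 2 (within the scatter), which exchanges one small group for another on an aromatic carbon and leaves the number within the scatter. That step does not involve methoxyoxy, so it speaks only loosely for the new change, but it does show that an exchange at this place need not move the number much. No step beyond the scatter is therefore expected in this assay for compound 3. Compound 3 is expected to give 90%, within 78% to 100%. The step this estimate means, a number 4.1 percentage points lower from compound 2 to compound 3 (within the scatter), is expected to stay within the scatter.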

Compound 3, a percentage reported as activity, at one concentration (the size of the read-out at that concentration, not a potency): 100%
Compound 3: the middle estimate sits 10 percentage points below what was measured, within the range that was stated.
By their numbers in this assay, from the lowest: compounds 1, 2 and 3 (each within the scatter of the next, the first and the last beyond it).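

In this assay, methoxyoxy in place of methyl on this aromatic carbon gives a number 5.9 percentage points higher from compound 2 to compound 3 (within the scatter), so a group with oxygen atoms and hydrogen-bond acceptors cannot be told apart from methyl here. Methoxyoxy in place of bromo gives a number 10.9 percentage points higher from compound 1 to compound 3 (beyond the scatter), the first step at this position to lie beyond the scatter, pointing to a modestly weaker effect at the concentration tested, although compound 2 remains within the scatter of both other compounds. Nothing measured here gives a reason for either step.

Still open, as far as these compounds go, is whether an amine, a carboxylic acid or a longer chain on this aromatic carbon would keep the number in the same narrow band. Also open, from the compounds shown here alone, is whether any group at this position could produce a clearly stronger effect in this assay.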